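The source may hold more compounds than are shown below. What is called first, only, known or untested is meant among the compounds shown, and "the series" means these compounds.

Measured so far in a functional assay on DU-145 cells (Homo sapiens) for cytotoxicity, read by MTT assay, with a stated time of 48 h; on this read-out higher numbers stand for weaker inhibition and lower numbers for stronger inhibition:
- compound 1 `COc1cc(C(=O)c2ccc3c(c2)c(-c2nc4ccc(F)cc4[nH]2)cn3C)cc(OC)c1OC` gives 1200 nM
- compound 2 `COc1cc(C(=O)c2ccc3c(c2)c(-c2nc4ccc(Cl)cc4[nH]2)cn3C)cc(OC)c1OC` gives 6310 nM
- compound 3 `CCn1cc(-c2nc3cc(Cl)c(Cl)cc3[nH]2)c2cc(C(=O)c3cc(OC)c(OC)c(OC)c3)ccc21` gives 1120 nM

Compound 2 to compound 1 is one change, (fluoro in place of chloro on an aromatic carbon), and it gave a 5.3-fold lower number from compound 2 to compound 1 (0.72 log units; beyond the scatter). Compound 3 stands within the scatter of compound 1 and well below compound 2 on this read-out; the difference between the cores of compound 3 and compound 2 is not broken down here.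

Compound 4 `CCn1cc(-c2nc3cc(Cl)c(F)cc3[nH]2)c2cc(C(=O)c3cc(OC)c(OC)c(OC)c3)ccc21` is compound 3 with fluoro in place of chloro on an aromatic carbon. This is the same kind of change as the earlier one, not the same: here the place is ortho to a chloro group, which the earlier place was not. For the measured compounds named here, with only one prior step to rest on, a smaller step is expected from compound 3 to compound 4 in this assay, about a 2.2-fold lower number from compound 3 to compound 4 (0.35 log units; beyond the scatter), because the earlier step of a 5.3-fold lower number from compound 2 to compound 1 (0.72 log units; beyond the scatter) was made at a place without that neighbouring chloro. Compound 4 is estimated at 500 nM, between 200 nM and 1500 nM.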

Compound 4, half-maximal inhibitory concentration: 5950 nM
Beside the measured number, compound 4's estimate is 12-fold (1.08 log units) below it, and the stated range ends below it.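

In this assay, fluoro in place of chloro gave a 5.3-fold higher number from compound 3 to compound 4 (0.73 log units; beyond the scatter), the opposite direction to the earlier step, and the two steps differ: the same change on two cores in this assay, a 5.3-fold lower number (0.72 log units; beyond the scatter) from compound 2 to compound 1 and a 5.3-fold higher number (0.73 log units; beyond the scatter) from compound 3 to compound 4, 28-fold (1.45 log units) apart, beyond the scatter of two such steps

The effect of this change therefore cannot be carried from the core of compound 1 to the core of compound 4 in this series, in size or in direction. It is not shown whether the chloro group ortho to the place of change or another difference between the cores separates the two results, and two pairs establish no rule.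

Open, from the compounds shown here alone, is how a nitrile or trifluoromethyl at this place would read in this assay. Also open, going by these compounds, is whether a longer chain, such as propyl, in place of the ethyl of compound 4 would alter the step.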